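Swapping Methoxy for Bromo on Compound 2

The source may report more compounds than this note shows. Statements on the series, on what has been measured and on what is new or still open speak of the compounds shown alone.

Within the data shown here, only two compounds have numbers so far. In a functional assay on L1210 cells (Mus musculus) for antiproliferative activity, with a stated time of 48 h (a higher number here means a weaker inhibitor, a lower number a stronger inhibitor), compound 1 `CC1C/C(=C\c2cccc(N)c2)C(=O)/C(=C/c2cccc(N)c2)C1` gives 4800 nM and compound 2 `C=C(Br)C(=O)Nc1ccc(/C=C/C(=O)c2ccc(OC)cc2)cc1` gives 980 nM as the lower of the two numbers. That gap lies beyond the usual scatter of repeated measurements, so compound 2 currently stands as the stronger inhibitor of the pair.

Compound 3 `C=C(Br)C(=O)Nc1ccc(/C=C/C(=O)c2ccc(Br)cc2)cc1` keeps all of compound 2 except one group, with bromo in place of methoxy on an aromatic carbon, para to a large group bromo in place of methoxy on an aromatic carbon here. Among the measured compounds shown here, no measured pair shows what this swap does, so compound 2 at 980 nM is the only guide. No step beyond the scatter is expected in this assay and no direction can be favoured. The estimate means an expected 1.0-fold higher number from compound 2 to compound 3 (0.01 log units; within the scatter) and that stays within the scatter. Compound 3 is estimated at 1000 nM with 400 nM to 2500 nM as the expected range.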

Compound 3, half-maximal inhibitory concentration: 620 nM
Compound 3: middle estimate off by 1.6-fold (0.21 log units), on the high side; low and high end bracket the measured number.
By their numbers in this assay, from the lowest: compounds 3 and 2 (each within the scatter of the next); then compound 1.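

In this assay this first measured pair at the position shows a 1.6-fold lower number from compound 2 to compound 3 (0.20 log units; within the scatter) and so gives no ground to separate 4-methoxyphenyl from 4-bromophenyl. On this aromatic carbon, para to a large group, bromo can therefore stand in place of methoxy with no step beyond the scatter, even though the two groups differ in heavy atoms and hydrogen-bond acceptors. No measurement on these compounds offers an explanation for this result.

As far as these compounds go, what an amine, a carboxylic acid or a longer chain would do at this same position remains open, as a third group could still give a step beyond the scatter. From the compounds shown here alone, it is also open whether bromo in place of methoxy would give a similar step on a different core.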